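A Smaller Ring at the End of the Side Chain

A few compounds are considered here, and "the series" means these few. Any claim that something is new, unique, unknown or untested is made for them only; others in the source may bear on it.

Of the compounds shown here, three that share one core have been tested in a functional assay on A-431 cells (Homo sapiens) for antiproliferative activity, read by MTT assay, with a stated time of 72 h; on this read-out lower numbers stand for stronger inhibition and higher numbers for weaker inhibition. Compound 1 `COc1cc2ncnc(Nc3ccc(F)c(Br)c3)c2cc1OCCCN1CCNCCNCCNCC1` gives 1580 nM. Compound 2 `COc1cccc(Nc2ncnc3cc(OC)c(OCCCN4CCNCCNCCNCC4)cc23)c1` gives 3210 nM, and compound 3 `COc1cc2ncnc(Nc3cccc(I)c3)c2cc1OCCCN1CCNCCNCCNCC1` gives 2540 nM. Among these three numbers, compound 3 stands second highest; its nearest neighbour is compound 2 and its furthest is compound 1, and both gaps are within the usual scatter, so no firm ordering among them can be read.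

The measured steps are a 2.0-fold higher number from compound 1 to compound 2 (0.31 log units; beyond the scatter), a 1.6-fold higher number from compound 1 to compound 3 (0.21 log units; within the scatter) and a 1.3-fold lower number from compound 2 to compound 3 (0.10 log units; within the scatter). Each of them changes only the group on the nitrogen on the aromatic ring, and none touches the side chain.

Compound 4 `COc1cc2ncnc(Nc3cccc(I)c3)c2cc1OCCCN1CCNCCNCC1` differs from compound 3 in a different place: a group of 9 heavy atoms (6 carbon, 3 nitrogen; one nine-membered non-aromatic ring with 3 hetero atoms) in place of a group of 12 heavy atoms (8 carbon, 4 nitrogen; one twelve-membered non-aromatic ring with 4 hetero atoms), on a saturated chain carbon, three bonds along the chain from an oxygen on an aromatic ring. For the measured compounds named here, none of the measured steps bears on this change, so the data give no direction for it. The working expectation is a step that does not go beyond the scatter, a 1.0-fold lower number from compound 3 to compound 4 (0.01 log units; within the scatter), held with a wide range. Compound 4 is therefore expected to give about 2500 nM in this assay, with a range from 800 nM to 8000 nM.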

Compound 4, half-maximal inhibitory concentration: 2220 nM
Estimate against measurement, compound 4: 1.1-fold (0.05 log units) above; the measured number falls inside the stated range.
By their numbers in this assay, from the lowest: compounds 1, 4, 3 and 2 (each within the scatter of the next, the first and the last beyond it).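

For the compounds shown here, until now every measured step changed only the group on the nitrogen on the aromatic ring, so the end of the side chain had no step of its own. In this assay, replacing the larger non-aromatic ring with 4 hetero atoms by the nine-membered one with 3 hetero atoms gives a 1.1-fold lower number from compound 3 to compound 4 (0.06 log units; within the scatter) and leaves the two compounds indistinguishable, so on this 3-iodophenyl compound the assay tolerates the smaller ring, which also has one hydrogen-bond donor and one hydrogen-bond acceptor fewer. No measurement shown here offers an explanation for this result.

As far as these compounds go, this is a single pair, so it remains open whether the nine-membered ring would behave the same way with the 3-bromo-4-fluorophenyl group of compound 1 or the 3-methoxyphenyl group of compound 2. From the compounds shown here alone, it also remains open how far the end of the chain can be simplified, for example to a six-membered piperazine ring, a morpholine ring or a plain dimethylamino group, and whether a longer chain carrying the same rings would read any differently.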